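Methyl for fluoro on the cyclopropane of compound 3

The compounds below may be only part of what the source reports. "The series", "measured", "known", "first", "only" and "open" are said of these compounds alone.

Three compounds share one core and differ only in how the fluorocyclopropane is drawn. Compound 1 `O=C([C@H]1C[C@H]1F)N1CC2CC(C1)N2` gives 62 nM in an assay on CHO cells for agonist activity at Neuronal acetylcholine receptor; alpha3/alpha6/beta2/beta3 (Homo sapiens), read by FLIPR and calcium flux; a higher number here means that more compound is needed for the effect, a lower number that less compound is needed. Compound 2 `O=C([C@H]1C[C@@H]1F)N1CC2CC(C1)N2` gives 620 nM, and compound 3 `O=C([C@@H]1C[C@H]1F)N1CC2CC(C1)N2` gives 53 nM. Compound 3 sits at the lowest number of the three, with compound 1 close by and compound 2 well apart: the step of a 1.2-fold lower number from compound 1 to compound 3 (0.07 log units; within the scatter) stays within the scatter, while a 10-fold higher number from compound 1 to compound 2 (1.00 log units; beyond the scatter) and a 12-fold lower number from compound 2 to compound 3 (1.07 log units; beyond the scatter) lie beyond it, and the only thing that separates those pairs is the drawn configuration, as the fact that one of compounds 1 and 2 is drawn with a defined configuration and the other without, at the place where they differ and the fact that one of compounds 2 and 3 is drawn with a defined configuration and the other without, at the place where they differ record.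

Compound 4 `C[C@@H]1C[C@H]1C(=O)N1CC2CC(C1)N2` is reached from compound 3 by a different kind of change: methyl in place of fluoro on a saturated ring carbon. Going by the values given here, none of the measured steps swaps one group for another; all three concern the drawn configuration only, so they say nothing direct about this exchange. Without a comparable step, a small shift is expected rather than a large one, and its direction is uncertain. Compound 4 is therefore estimated at 100 nM, within 25 nM to 400 nM, which corresponds to an expected step of a 1.9-fold higher number from compound 3 to compound 4 (0.28 log units; within the scatter).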

Compound 4, half-maximal effective concentration: 51 nM
For compound 4 the middle estimate is 2.0-fold (0.29 log units) above the measured one; low and high end bracket the measured number.
By their numbers in this assay, from the lowest: compounds 4, 3 and 1 (each within the scatter of the next); then compound 2.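

In this assay, putting methyl in place of fluoro on this saturated ring carbon leaves the number within the scatter: a 1.0-fold lower number from compound 3 to compound 4 (0.02 log units; within the scatter). Going by these compounds alone, this is the first step that swaps one group for another rather than changing a drawn configuration, and in this pair the read-out does not separate 2-methylcyclopropyl from 2-fluorocyclopropyl. The two wider comparisons place compound 4 with compounds 1 and 3 and apart from compound 2, with one step inside the scatter and the other well beyond it: a 1.2-fold lower number from compound 1 to compound 4 (0.08 log units; within the scatter) and a 12-fold lower number from compound 2 to compound 4 (1.08 log units; beyond the scatter).

Nothing shown explains why methyl and fluoro give such similar numbers at this position. This single exchange also leaves open whether methyl would match fluoro in the arrangement drawn in compound 2, and how a longer chain such as ethyl, or an amine or a hydroxyl on the same ring carbon, would read in this assay.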